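A Second Methoxy Group Added to the Cinnamoyl Ring

This account rests on a few compounds, and the source may have more. Where it says the series, first, only, none or still open, it means among the compounds named here.

Compound 1 `O=C(/C=C/c1ccccc1)c1cc2ccoc2cc1O` gives 67.6% in an assay on isolated protein for inhibition of lysosomal alpha-glucosidase (Rattus norvegicus), read by spectrophotometry, with a stated time of 5 min, tested at 25 ug/mL; on this read-out higher numbers stand for more inhibition at the one concentration tested (going by the name of the read-out) and lower numbers for less inhibition. For the measured compounds named here, compound 2 `COc1ccc(/C=C/C(=O)c2cc3ccoc3cc2O)cc1` gives 48.9% in this assay, the lower of the two numbers known. Going by the values given here, the only measured step, a number 18.7 percentage points lower from compound 1 to compound 2 (beyond the scatter), was itself a methoxy in place of hydrogen on an aromatic carbon. Compound 3 `COc1ccc(/C=C/C(=O)c2cc3ccoc3cc2O)cc1OC` differs from compound 2 by methoxy in place of hydrogen on an aromatic carbon. Because a number 18.7 percentage points lower from compound 1 to compound 2 (beyond the scatter) was a modest loss, a further but uncertain loss is expected. For compound 3 the expected step is a number 8.9 percentage points lower from compound 2 to compound 3 (within the scatter). Compound 3 is therefore estimated at 40%, within 25% to 55%.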

Compound 3, a percentage reported as inhibition, at one concentration (the size of the read-out at that concentration, not a potency): 89.4%
Compound 3: middle estimate off by 49.4 percentage points, on the low side; measured number above the stated range.
By their numbers in this assay, from the lowest: compound 2; then compound 1; then compound 3.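

The same change, methoxy in place of hydrogen, lowered the number at the first ring position tested (a number 18.7 percentage points lower from compound 1 to compound 2 (beyond the scatter)) but raises it at this place, ortho to a methoxy group (a number 40.5 percentage points higher from compound 2 to compound 3 (beyond the scatter)). In this assay, the result of adding a methoxy therefore depends on where it goes or on what the ring already carries, so single steps cannot simply be added up. Nothing available here accounts for this reversal.

Still open, as far as these compounds go, is whether this methoxy would give a gain without the first methoxy on the ring. From the compounds shown here alone, it is also open whether an amine or a longer ethoxy chain at this place would behave like methoxy.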